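The source may report more compounds than this note shows. Statements on the series, on what has been measured and on what is new or still open speak of the compounds shown alone.

Measured compounds:
compound 1, `COc1cc(OC)c(C(=O)/C=C/c2cn(-c3ccccc3)nc2-c2cccnc2)c(OC)c1`, 500 nM
compound 2, `COc1ccc(C(=O)/C=C/c2cn(-c3ccccc3)nc2-c2cccnc2)c(OC)c1OC`, 2300 nM
compound 3, `COc1cc(OC)c(C(=O)/C=C/c2cn(-c3ccccc3)nc2-c2ccncc2)c(OC)c1`, 2600 nM

In a functional assay on Huh-7 cells (Homo sapiens) for inhibition, read by sulforhodamine B assay, with a stated time of 72 h (on this read-out higher numbers stand for weaker inhibition and lower numbers for stronger inhibition), compound 1 gives 500 nM. Compound 3 differs from it in one place, (pyridin-4-yl in place of pyridin-3-yl on an aromatic carbon), and this change brought a 5.2-fold higher number from compound 1 to compound 3 (0.72 log units; beyond the scatter). Compound 2 gives 2300 nM in this assay, a number that lies within the usual scatter of the value of compound 3; the difference between the core of compound 2 and the core of compound 1 is not broken down here. Compound 4, `COc1ccc(C(=O)/C=C/c2cn(-c3ccccc3)nc2-c2ccncc2)c(OC)c1OC`, carries the same change as compound 3 but on the core of compound 2: pyridin-4-yl in place of pyridin-3-yl on an aromatic carbon. Because the step of a 5.2-fold higher number from compound 1 to compound 3 (0.72 log units; beyond the scatter) was modest but beyond the scatter, a step of similar size is expected here, a 3.9-fold higher number from compound 2 to compound 4 (0.59 log units; beyond the scatter). Compound 4 is therefore estimated at 9000 nM in this assay, with a likely range from 3000 nM to 30000 nM.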

Compound 4, half-maximal inhibitory concentration: 3700 nM
Estimate against measurement, compound 4: 2.4-fold (0.39 log units) above; the range from low to high includes it.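

Replacing pyridin-3-yl with pyridin-4-yl gives a 1.6-fold higher number from compound 2 to compound 4 (0.21 log units; within the scatter) in this assay, so on this core the effect of the change cannot be told apart from the scatter. The change therefore did not carry over at the same size from one core to the other: the same change on two cores in this assay, a 5.2-fold higher number (0.72 log units; beyond the scatter) from compound 1 to compound 3 and a 1.6-fold higher number (0.21 log units; within the scatter) from compound 2 to compound 4, 3.2-fold (0.51 log units) apart, beyond the scatter of two such steps. For the compounds shown here, this shows that a step measured on one core is a poor guide to its size on the other, but with only two cores it does not show why they differ or what would happen on a third.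

The compounds shown leave open how a pyridin-2-yl ring or an amine would fare at this place on either core. They also leave open whether a hydroxy group in place of a methoxy group would alter the result.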